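The source may hold more compounds than are shown below. What is called first, only, known or untested is meant among the compounds shown, and "the series" means these compounds.

Compound 1 `CC(C)(C)c1ccc(C(=O)N2CCC3(CC2)C(=O)N(CC(=O)N2CCNCC2)CN3c2ccccc2)cc1`: 22000 nM
Compound 2 `CC(C)(C)OC(=O)NCCNC(=O)CN1CN(c2ccccc2)C2(CCN(C(=O)c3ccc(C(C)(C)C)cc3)CC2)C1=O`: 10900 nM
Compound 3 `CC(C)(C)c1ccc(C(=O)N2CCC3(CC2)C(=O)N(CC(=O)NCCCCO)CN3c2ccccc2)cc1`: 19200 nM

All three were measured in an assay on HEK293 cells for displacement of a labelled ligand from NPC1-like intracellular cholesterol transporter 1 (Homo sapiens); on this read-out higher numbers stand for weaker inhibition and lower numbers for stronger inhibition. Compound 3 stands second highest of these three numbers; its nearest neighbour is compound 1, and the step of a 1.1-fold lower number from compound 1 to compound 3 (0.06 log units; within the scatter) lies within the scatter, as does the step of a 1.8-fold higher number from compound 2 to compound 3 (0.25 log units; within the scatter). Compound 4 `CC(C)(C)c1ccc(C(=O)N2CCC3(CC2)C(=O)N(CC(=O)NCN)CN3c2ccccc2)cc1` differs from compound 3 by amino in place of 3-hydroxypropyl on a saturated chain carbon bound to an amide-type nitrogen. The three measured steps all alter the same side chain on the carbonyl carbon, and none of them moves the number beyond the scatter: a 2.0-fold lower number from compound 1 to compound 2 (0.30 log units; within the scatter), a 1.1-fold lower number from compound 1 to compound 3 (0.06 log units; within the scatter) and a 1.8-fold higher number from compound 2 to compound 3 (0.25 log units; within the scatter). On that basis compound 4 is expected to show no step beyond the scatter, a 1.0-fold lower number from compound 3 to compound 4 (0.00 log units; within the scatter). Compound 4 is therefore estimated at 19000 nM, with a range from 8000 nM to 45000 nM.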

Compound 4, half-maximal inhibitory concentration: 26500 nM
For compound 4 the middle estimate is 1.4-fold (0.14 log units) below the measured one, and the stated range covers the measured number.
By their numbers in this assay, from the lowest: compounds 2, 3, 1 and 4 (each within the scatter of the next, the first and the last beyond it).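

Swapping 3-hydroxypropyl for amino on a saturated chain carbon bound to an amide-type nitrogen leaves the number within the scatter (a 1.4-fold higher number from compound 3 to compound 4 (0.14 log units; within the scatter)), and the (aminomethyl)amino end likewise stays within the scatter of the piperazin-1-yl end (a 1.2-fold higher number from compound 1 to compound 4 (0.08 log units; within the scatter)). This side chain now gives its first step beyond the scatter, a modest one against the (tert-butoxycarbonyl)amino chain (a 2.4-fold higher number from compound 2 to compound 4 (0.39 log units; beyond the scatter)). Nothing available here bears on the reason for that step.

From the compounds shown here alone, whether a carboxylic acid at the end of this side chain would give a larger step remains open. So does whether a longer chain carrying an amine would.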